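Chemokine receptor antagonist series: triazole in place of bicyclic amide side group

The source may report more compounds than this note shows. Statements on the series, on what has been measured and on what is new or still open speak of the compounds shown alone.

Measured so far:
compound 1 `COc1ccc(-c2nc(C(F)(F)F)sc2N2CCN(C(=O)Cn3cnc4cccnc43)[C@H](C)C2)cc1` gives 131 nM in a functional assay on U2OS cells for antagonist activity at C-X-C chemokine receptor type 3 (Homo sapiens), read by beta-arrestin recruitment; on this read-out lower numbers stand for stronger inhibition and higher numbers for weaker inhibition
compound 2 `CCOc1ncc(-c2nc(C(F)(F)F)sc2N2CCN(C(=O)Cn3ncc4cccnc43)[C@H](C)C2)cn1` gives 55 nM in this assay

Compound 2 has the lowest number of the two in this assay; compound 1 gives a higher number, and the gap between them lies beyond the scatter. Within the data shown here, the two measured compounds differ at more than one place, so no isolated step is available.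

Compound 3 `CCOc1ncc(-c2nc(C(F)(F)F)sc2N2CCN(C(=O)Cn3nc(C)nc3C)[C@H](C)C2)cn1` differs from compound 2 by a group of 7 heavy atoms (4 carbon, 3 nitrogen; one five-membered aromatic ring with 3 hetero atoms) in place of a group of 9 heavy atoms (6 carbon, 3 nitrogen; one five-membered aromatic ring with 2 hetero atoms, one six-membered aromatic ring with 1 hetero atom), on a saturated chain carbon bound to a carbonyl carbon. Among the measured compounds shown here, no measured pair shows this change, so the expectation rests on the series as a whole. The step is estimated as a 2.2-fold higher number from compound 2 to compound 3 (0.34 log units; beyond the scatter), a modest weakening, with a real chance that it stays within the scatter. Compound 3 is expected to give about 120 nM in this assay, within 40 nM to 400 nM.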

Compound 3, half-maximal inhibitory concentration: 173 nM
For compound 3 the middle estimate is 1.4-fold (0.16 log units) below the measured one; low and high end bracket the measured number.
By their numbers in this assay, from the lowest: compound 2; then compounds 1 and 3 (each within the scatter of the next).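

In this assay there is a 3.1-fold higher number from compound 2 to compound 3 (0.50 log units; beyond the scatter) on exchanging the two-ring group for 3,5-dimethyl-1H-1,2,4-triazol-1-yl on the saturated chain carbon bound to a carbonyl carbon. Among these compounds, this is the first isolated step, and it shows that the group at this place affects the read-out by more than the scatter, although the single aromatic ring still leaves measurable inhibition. Hydrogen-bond donor and acceptor counts are the same for the two groups, so those counts do not distinguish them, and no measurement shown accounts for the step.

As far as these compounds go, it remains open whether the two methyl groups of the triazole contribute, which a triazole carrying hydrogen in their place or a triazole with ethyl groups would test. From the compounds shown here alone, it is also open whether the step carries over to the core of compound 1.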